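A few compounds are considered here, and "the series" means these few. Any claim that something is new, unique, unknown or untested is made for them only; others in the source may bear on it.

Measured so far:
compound 1 `Cc1nnc(CNC(=O)CN)n1-c1ccc(Cl)cc1C(=O)c1ccccc1` — 4.25 mg/kg
compound 2 `CN(C(=O)CNC(=O)CN)c1ccc(Cl)cc1C(=O)c1ccccc1Cl` — 1.4 mg/kg
compound 3 `Cc1nnc(CNC(=O)CN)n1-c1ccc(Cl)cc1C(=O)c1ccccc1Cl` — 0.31 mg/kg

In a functional assay on the whole organism for inhibition, with Mus musculus as the target (a higher number here means that more compound is needed for the effect, a lower number that less compound is needed), compound 3 gives 0.31 mg/kg, the lowest number of the three; compound 2 gives 1.4 mg/kg and compound 1 gives 4.25 mg/kg, both beyond the scatter from compound 3. Compound 1 differs from compound 3 by hydrogen in place of chloro on an aromatic carbon, and that change made a 14-fold higher number from compound 3 to compound 1 (1.14 log units; beyond the scatter). Compound 4 `CN(C(=O)CNC(=O)CN)c1ccc(Cl)cc1C(=O)c1ccccc1` is not yet measured in this assay; it differs from compound 2 by hydrogen in place of chloro on an aromatic carbon, the same change at the same place. The difference between the core of compound 2 and the core of compound 3 is not broken down here. A step of a 10-fold higher number from compound 2 to compound 4 (1.00 log units; beyond the scatter) is expected in this assay, somewhat smaller than the measured one because a 14-fold higher number from compound 3 to compound 1 (1.14 log units; beyond the scatter) stands on a different core and carries over only as a guide. Compound 4 is thus expected at 14 mg/kg, between 5 mg/kg and 40 mg/kg.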

Compound 4, dose for half-maximal effect: 15.2 mg/kg
Compound 4: middle estimate off by 1.1-fold (0.04 log units), on the low side, within the range that was stated.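

In this assay, going from 2-chlorophenyl to phenyl gives an 11-fold higher number from compound 2 to compound 4 (1.04 log units; beyond the scatter). The change carries from one core to the other with its size preserved: the same change on two cores in this assay, a 14-fold higher number (1.14 log units; beyond the scatter) from compound 3 to compound 1 and an 11-fold higher number (1.04 log units; beyond the scatter) from compound 2 to compound 4, 1.3-fold (0.10 log units) apart, within the scatter of two such steps. This shows agreement across two pairs on two cores in a single assay, but it does not show that the step would hold on a further core, and it does not explain why the chloro matters.

The compounds shown carry only chloro or hydrogen at this place on the ring, so the outcome with fluoro, methyl or methoxy there remains open. The amine-bearing chain is common to all four compounds, so the effect of a longer chain in its place is open too.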